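Ethoxy for methyl on the amide aryl ring

The compounds below may be only part of what the source reports. "The series", "measured", "known", "first", "only" and "open" are said of these compounds alone.

Compound 1 `C=CC1=C(C(=O)Nc2ccc(OCC)cc2)C(c2ccc(OC)cc2)OC1` gives 17600 nM in a functional assay on A549 cells (Homo sapiens) for cytotoxicity, read by MTT assay, with a stated time of 24 h; a lower number here means a stronger inhibitor, a higher number a weaker inhibitor.
Compound 2 `C=CC1=C(C(=O)Nc2ccc(C)cc2)C(c2ccc(F)cc2)OC1` gives only a limit, > 100000 nM, in this assay.
Compound 3 `C=CC1=C(C(=O)NC2CCCCC2)C(c2ccc(F)cc2)OC1` likewise gives only a limit, > 100000 nM, in this assay.

Compound 2 stands at the limit of this assay and carries no number of its own. Compound 3 sits at the same limit, so the step that the two limits leave unreadable from compound 2 to compound 3 cannot be read. Compound 1, which differs from compound 2 in two places, is the only one of the three with a measured value.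

Compound 4 `C=CC1=C(C(=O)Nc2ccc(OCC)cc2)C(c2ccc(F)cc2)OC1` differs from compound 2 by ethoxy in place of methyl on an aromatic carbon. Going by the values given here, no measured step bears directly on this change: the one step on record is blocked by the limit described in the limit of > 100000 nM in this assay, at which 2 of the 3 values shown sit, and compound 1 shares the ethoxy group but not the second aryl ring. Compound 4 is therefore expected to lie near the weaker end of this assay, and the step of an at least 1.6-fold lower number from compound 2 to compound 4 (0.22 log units; that floor lies within the scatter) is an estimate only, with a real chance that compound 4 also returns a limit. Compound 4 is estimated at 60000 nM, with a range from 15000 nM to 200000 nM.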

Compound 4, half-maximal inhibitory concentration: "not active" (no number reported)
Compound 4 has no reported number here, and the estimate cannot be compared.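

Going by these compounds alone, compound 4 is reported as not active in this assay, with no number, and no step from compound 2 to compound 4 can be read. The compounds shown leave open whether ethoxy in place of methyl changes the result in this assay at all.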